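Methoxy for methyl on a sulfonate ester: a repeated step

The source may hold more compounds than are shown below. What is called first, only, known or untested is meant among the compounds shown, and "the series" means these compounds.

Compound 1 `Cc1ccc(S(=O)(=O)Oc2ccccc2/C=C(\C#N)C(=O)Nc2nnc(Cc3cccc4ccccc34)s2)cc1` and compound 2 `COc1ccc(S(=O)(=O)Oc2ccccc2/C=C(\C#N)C(=O)Nc2nnc(Cc3cccc4ccccc34)s2)cc1` share a core and differ in one place, (methoxy in place of methyl on an aromatic carbon). In a functional assay on HL-60 cells (Homo sapiens) for inhibition, read by CCK-8 assay, with a stated time of 48 h, tested at 20 uM (a higher number here means more inhibition of growth at the concentration tested, a lower number less inhibition of growth), compound 1 gives 19%, while compound 2 gives 98%, so the step of a number 79 percentage points higher from compound 1 to compound 2 (beyond the scatter) is large. Compound 3 `Cc1ccc(Cc2nnc(NC(=O)/C(C#N)=C/c3ccccc3OS(=O)(=O)c3ccc(C)cc3)s2)cc1` differs from compound 1 by 4-methylphenyl in place of naphthalen-1-yl on a saturated chain carbon bound to an aromatic carbon, and in this assay compound 3 gives 17%, a step of a number 2 percentage points lower from compound 1 to compound 3 (within the scatter) that is within the scatter. Compound 4 `COc1ccc(S(=O)(=O)Oc2ccccc2/C=C(\C#N)C(=O)Nc2nnc(Cc3ccc(C)cc3)s2)cc1` has not been measured; it differs from compound 3 by methoxy in place of methyl on an aromatic carbon, the same change as between compound 1 and compound 2, made on the same kind of place. Because the earlier step of a number 79 percentage points higher from compound 1 to compound 2 (beyond the scatter) was large, and because the core change a number 2 percentage points lower from compound 1 to compound 3 (within the scatter) hardly moved the number, compound 4 is expected to rise by about a number 68 percentage points higher from compound 3 to compound 4 (beyond the scatter). The estimate for compound 4 in this assay is 85%, between 40% and 100%, resting on one precedent only.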

Compound 4, percent growth inhibition at one concentration: 100%
Estimate against measurement, compound 4: 15 percentage points below; measured number inside the range.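

In this assay, methoxy in place of methyl gives a number 83 percentage points higher from compound 3 to compound 4 (beyond the scatter), so the change carried over to a second core with much the same size: the same change on two cores in this assay, a number 79 percentage points higher (beyond the scatter) from compound 1 to compound 2 and a number 83 percentage points higher (beyond the scatter) from compound 3 to compound 4, 4 percentage points apart, within the scatter of two such steps. With methoxy present, 4-methylphenyl in place of naphthalen-1-yl gives a number 2 percentage points higher from compound 2 to compound 4 (within the scatter), and the same swap made no clear difference with methyl present either: the same change on two cores in this assay, a number 2 percentage points lower (within the scatter) from compound 1 to compound 3 and a number 2 percentage points higher (within the scatter) from compound 2 to compound 4, 4 percentage points apart, within the scatter of two such steps. Within the data shown here, this rests on only two cores tested at one concentration, so it says nothing about other cores, and it cannot separate compound 2 from compound 4 in strength.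

The compounds shown leave open whether the large rise is specific to methoxy or would also come with another group in its place, such as ethoxy, an amine or a fluorine atom.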